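The compounds below may be only part of what the source reports. "The series", "measured", "known", "first", "only" and "open" are said of these compounds alone.

Compound 1 `COc1ccc(C(c2ccc(OC)cc2)N2CCN(C(=O)COc3ccc4ccccc4c3)CC2)cc1` carries a (naphthalen-2-yl)oxy group on its acetyl piperazine arm. In a functional assay on PC-12 cells (Rattus norvegicus) for cytotoxicity, read by MTT assay, with a stated time of 24 h, tested at 10 uM (on this read-out higher numbers stand for a stronger effect at the one concentration tested and lower numbers for a weaker effect), compound 1 gives 25.6%. Compound 3 `COc1ccc(OCC(=O)N2CCN(C(c3ccc(OC)cc3)c3ccc(OC)cc3)CC2)cc1` differs from it in one place only, (4-methoxyphenyl in place of naphthalen-2-yl on an oxygen on a saturated carbon), and in this assay compound 3 gives 56.7%. The change is therefore worth a step of a number 31.1 percentage points higher from compound 1 to compound 3 (beyond the scatter).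

Compound 2 `O=C(COc1ccc2ccccc2c1)N1CCN(C(c2ccc(Br)cc2)c2ccc(Br)cc2)CC1` keeps the naphthalene arm of compound 1 but has a different core; the difference between the two cores is not broken down here. In this assay compound 2 gives 30.2%, which sits within the scatter of the value of compound 1, so the two cannot be ranked against each other. The value of compound 3 stands beyond the scatter above both.

Compound 4 `COc1ccc(OCC(=O)N2CCN(C(c3ccc(Br)cc3)c3ccc(Br)cc3)CC2)cc1` has not yet been measured. It relates to compound 2 as compound 3 relates to compound 1: 4-methoxyphenyl in place of naphthalen-2-yl on an oxygen on a saturated carbon. The place of the change is described in the same words in both pairs, so it is the same change made on a second core. The expectation is that compound 4 will move by about a number 25.8 percentage points higher from compound 2 to compound 4 (beyond the scatter), a step of similar size to a number 31.1 percentage points higher from compound 1 to compound 3 (beyond the scatter), because compound 2 gives 30.2% from which the same change would start. On that basis compound 4 is expected to reach about 56%, with a likely range from 40% to 72%. This rests on a single earlier instance of the change, so the estimate carries real uncertainty.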

Compound 4, a percentage reported as activity, at one concentration (the size of the read-out at that concentration, not a potency): 50.3%
For compound 4 the middle estimate is 5.7 percentage points above the measured one, within the range that was stated.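

On the second core, replacing naphthalen-2-yl with 4-methoxyphenyl on the oxygen gives, in this assay, a number 20.1 percentage points higher from compound 2 to compound 4 (beyond the scatter), so the change acts in the same direction on both cores. Set beside the earlier step, the sizes of the two steps cannot be told apart: the same change on two cores in this assay, a number 31.1 percentage points higher (beyond the scatter) from compound 1 to compound 3 and a number 20.1 percentage points higher (beyond the scatter) from compound 2 to compound 4, 11 percentage points apart, within the scatter of two such steps. This shows that, for these two pairs, the change carries from one core to the other, but two cores are too few to show that it would carry to any further core, and a reading at one concentration is no measure of potency or of why the number rises.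

A single swap removes one of the two aromatic rings and also brings in the oxygen of the methoxy group, so the compounds shown leave open which of these two differences accounts for the step, a question that a plain phenyl on the same oxygen could help to answer. Also open, as far as these compounds go, is how the read-out would respond to a carboxylic acid or a dimethylamino group on that ring, or to a longer chain in place of the saturated carbon that carries the oxygen.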